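The compounds below may be only part of what the source reports. "The series", "measured", "known", "first", "only" and "open" are said of these compounds alone.

Measured compounds in a functional assay on MDA-MB-231 cells (Homo sapiens) for cytotoxicity, read by MTT assay, with a stated time of 72 h; on this read-out higher numbers stand for weaker inhibition and lower numbers for stronger inhibition:
- compound 1 `O=C1c2c[n+]([O-])c3ccccc3c2C(=O)c2c1c1ccccc1n2Cc1cn([C@H]2C[C@H](O)[C@@H](CO)O2)nn1`: 580 nM
- compound 2 `O=C1c2c[n+]([O-])c3ccccc3c2C(=O)c2c1c1ccccc1n2Cc1cn(C[C@@H](O)CO)nn1`: 670 nM
- compound 3 `CC1(C)OC[C@@H](Cn2cc(Cn3c4c(c5ccccc53)C(=O)c3c[n+]([O-])c5ccccc5c3C4=O)nn2)O1`: reported only as a limit, > 1000 nM

Compound 2 gives the highest of the two numbers shown; its nearest neighbour is compound 1, with a 1.2-fold higher number from compound 1 to compound 2 (0.06 log units; within the scatter), so the two are indistinguishable here. Compound 3 sits at the limit of this assay (the limit of > 1000 nM in this assay, at which 1 of the 3 values shown sits). Among the measured compounds shown here, the step of an at least 1.4-fold higher number from compound 2 to compound 3 (0.17 log units; that floor lies within the scatter) therefore tells only that compound 3 is not stronger than compound 2.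

Compound 4 `CN(C)CCCCCn1c2c(c3ccccc31)C(=O)c1c[n+]([O-])c3ccccc3c1C2=O` is the next step from compound 2: 4-(dimethylamino)butyl in place of 1-(2,3-dihydroxypropyl)-1H-1,2,3-triazol-4-yl on a saturated chain carbon bound to an aromatic nitrogen

For the measured compounds named here, no measured step matches this change. The steps of a 1.2-fold higher number from compound 1 to compound 2 (0.06 log units; within the scatter) and an at least 1.4-fold higher number from compound 2 to compound 3 (0.17 log units; that floor lies within the scatter) swap groups on the same triazole-bearing chain, and all of them fall within the scatter; the triazole itself is kept in every measured compound. Compound 4 removes that ring entirely and introduces the 4-(dimethylamino)butyl chain, so nothing in the series sets its direction. The expectation is therefore no step beyond the scatter, with wide uncertainty. Compound 4 is expected to give 500 nM (range 200 nM to 1500 nM), an estimated step of a 1.3-fold lower number from compound 2 to compound 4 (0.13 log units; within the scatter).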

Compound 4, half-maximal inhibitory concentration: 240 nM
For compound 4 the middle estimate is 2.1-fold (0.32 log units) above the measured one; measured number inside the range.
By their numbers in this assay, from the lowest: compound 4; then compounds 1 and 2 (each within the scatter of the next). At a limit, above all of these: compound 3.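

In this assay, among the compounds shown here, putting 4-(dimethylamino)butyl in place of 1-(2,3-dihydroxypropyl)-1H-1,2,3-triazol-4-yl on a saturated chain carbon bound to an aromatic nitrogen gives a 2.8-fold lower number from compound 2 to compound 4 (0.45 log units; beyond the scatter), the only step printed as beyond the scatter. The triazole is therefore not required for cytotoxicity at this level, and this place tolerates a ring-free chain ending in a dimethylamino group. Nothing measured here accounts for the step.

The change removes the triazole and the two hydroxyl groups and adds the dimethylamino group in one move, so the step cannot be assigned to any one of these. Still open, on these data alone, is how a plain pentyl chain, a shorter or longer chain ending in dimethylamino, or a triazole carrying a dimethylaminoalkyl group would compare.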